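Swapping the trimethoxyphenyl for a small halophenyl

The compounds below may be only part of what the source reports. "The series", "measured", "known", "first", "only" and "open" are said of these compounds alone.

Compound 3 `C=CC(=O)Nc1cccc(NC(=O)CSc2nc(Nc3cc(OC)c(OC)c(OC)c3)c3ccccc3n2)c1` is the weakest of the three measured compounds in a functional assay on MDA-MB-231 cells (Homo sapiens) for inhibition, read by MTT assay, with a stated time of 72 h; a higher number here means a weaker inhibitor, a lower number a stronger inhibitor. In this assay compound 3 gives > 50000 nM, which is a limit of the assay and not a number. Compound 1 `C=CC(=O)Nc1cccc(NC(=O)CSc2nc(Nc3ccccc3)c3ccccc3n2)c1` gives 10200 nM, and compound 2 `C=CC(=O)Nc1cccc(NC(=O)CSc2nc(Nc3cccc(C)c3)c3ccccc3n2)c1` gives 16800 nM. The steps of an at least 4.9-fold higher number from compound 1 to compound 3 (0.69 log units; beyond the scatter) and an at least 2.9-fold higher number from compound 2 to compound 3 (0.47 log units; beyond the scatter) both point the same way, against the trimethoxyphenyl. Compound 4 `C=CC(=O)Nc1cccc(NC(=O)CSc2nc(Nc3ccc(F)c(Cl)c3)c3ccccc3n2)c1` reverses that direction: 3-chloro-4-fluorophenyl in place of 3,4,5-trimethoxyphenyl on a nitrogen on an aromatic ring. Both measured steps weakened inhibition on entering the trimethoxyphenyl, so the number for compound 4 is expected to fall back, a step of an at least 4.1-fold lower number from compound 3 to compound 4 (0.61 log units; beyond the scatter). Compound 4 is estimated at 12000 nM, within a range from 4000 nM to 50000 nM.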

Compound 4, half-maximal inhibitory concentration: 10600 nM
The estimate for compound 4 lay 1.1-fold (0.05 log units) above the measured number; the measured number falls inside the stated range.
By their numbers in this assay, from the lowest: compounds 1, 4 and 2 (each within the scatter of the next). At a limit, above all of these: compound 3.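

On a nitrogen on an aromatic ring, 3-chloro-4-fluorophenyl restores what 3,4,5-trimethoxyphenyl lost in this assay, with an at least 4.7-fold lower number from compound 3 to compound 4 (0.67 log units; beyond the scatter), a step read against a limit of the assay for compound 3. Against the two other groups, the halogens make no difference that can be told apart, with a 1.0-fold higher number from compound 1 to compound 4 (0.02 log units; within the scatter) and a 1.6-fold lower number from compound 2 to compound 4 (0.20 log units; within the scatter). Among the compounds shown, only the 3,4,5-trimethoxyphenyl stands apart, and a halogen-bearing phenyl now joins phenyl and 3-methylphenyl as tolerated here.

Going by these compounds, it stays open whether a single methoxy group on the phenyl is enough to weaken the number. On these data alone, it is also open whether a basic amine such as a dimethylamino group at this position would strengthen it.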